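The compounds below may be only part of what the source reports. "The series", "measured", "known", "first", "only" and "open" are said of these compounds alone.

Compound 3 `CNc1nc(Nc2ccc(C)c(N)c2)ncc1C(=O)Nc1cc(NC(=O)c2ccccc2OC)ccc1C` stands at a limit of an ADME assay on BaF3 cells (Mus musculus) for antiproliferative activity, read by CellTiter-Glo and CCK-8 assay, with a stated time of 72 h; a higher number here means a weaker inhibitor of growth, a lower number a stronger inhibitor of growth: in this assay compound 3 gives > 10000 nM, which is a limit and not a number. Compound 1 `CNc1cc(Nc2ncc3c(n2)N(C)C(=O)N(c2cc(NC(=O)c4cccc(C(F)(F)F)c4)ccc2C)C3)ccc1C` likewise returns only a limit in this assay, > 10000 nM. Compound 2 `CNc1nc(Nc2ccc(C)c([N+](=O)[O-])c2)ncc1C(=O)Nc1cc(NC(=O)c2ccccc2OC)ccc1C` also returns a limit in this assay, > 10000 nM. Within the data shown here, the one single-point step, amino in place of nitro, a step that the two limits leave unreadable from compound 2 to compound 3, is therefore unreadable; every value shown rests on (the limit of > 10000 nM in this assay, at which 3 of the 3 values shown sit). Compound 4 `CNc1nc(Nc2ccc(C)c(N)c2)ncc1C(=O)Nc1cc(NC(=O)c2ccc(OC)cc2)ccc1C` differs from compound 3 by 4-methoxyphenyl in place of 2-methoxyphenyl on a carbonyl carbon. Among the measured compounds shown here, no measured step bears on this change, and no step in the set is readable in size. The expected step in this assay is a step that the limit leaves unreadable from compound 3 to compound 4, nothing beyond the scatter. Compound 4 is expected to give about 20000 nM in this assay, within 5000 nM to 100000 nM, most likely again only as a limit.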

Compound 4, concentration for 50% growth inhibition: > 10000 nM
Compound 4 was reported as a limit; the forecaster's own chance of this, stated with the estimate: 80%; the middle value does not contradict the limit.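

No step can be read between compound 3 and compound 4: both are reported only as limits in this assay. The compounds shown leave open whether 2-methoxyphenyl or 4-methoxyphenyl on the carbonyl carbon changes growth inhibition at all, as every value rests on one point: the limit of > 10000 nM in this assay, at which 4 of the 4 values shown sit.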